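Three Measured Analogues and One Awaiting Its Number

This account rests on a few compounds, and the source may have more. Where it says the series, first, only, none or still open, it means among the compounds named here.

Compound 1 `CCS(=O)(=O)Nc1cc(-c2ccc3ncnc(Nc4cccc(F)c4)c3c2)cnc1OC` gives 2760 nM in a functional assay on SNU-638 cells (Homo sapiens) for cytotoxicity, read by sulforhodamine B assay, with a stated time of 72 h; on this read-out higher numbers stand for weaker inhibition and lower numbers for stronger inhibition.
Compound 2 `CCS(=O)(=O)Nc1cc(-c2ccc3ncnc(Nc4ccc(OC(F)(F)F)cc4)c3c2)cnc1OC` gives 22400 nM in this assay.
Compound 3 `CCS(=O)(=O)Nc1cc(-c2ccc3ncnc(Nc4ccc(OC)c(Cl)c4)c3c2)cnc1OC` gives 3620 nM in this assay.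

Compound 3 holds the second highest number of the three. Its nearest neighbour is compound 1, separated by a 1.3-fold higher number from compound 1 to compound 3 (0.12 log units; within the scatter); its furthest is compound 2, separated by a 6.2-fold lower number from compound 2 to compound 3 (0.79 log units; beyond the scatter), and the same group exchange also appears in an 8.1-fold higher number from compound 1 to compound 2 (0.91 log units; beyond the scatter). Compound 4 `CCS(=O)(=O)Nc1cc(-c2ccc3ncnc(Nc4ccc(Cl)c(C(=O)OC)c4)c3c2)cnc1OC` differs from compound 3 by 4-chloro-3-(methoxycarbonyl)phenyl in place of 3-chloro-4-methoxyphenyl on a nitrogen on an aromatic ring. For the measured compounds named here, no measured step carries this exact exchange, but the three steps show that swapping this group moves this assay by at most a modest amount. Compound 4 is therefore expected to show a small step, a 1.4-fold higher number from compound 3 to compound 4 (0.14 log units; within the scatter), in this assay. The estimated value of compound 4 is 5000 nM, within a range of 1500 nM to 20000 nM.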

Compound 4, half-maximal inhibitory concentration: 2200 nM
Beside the measured number, compound 4's estimate is 2.3-fold (0.36 log units) above it, and the stated range covers the measured number.
By their numbers in this assay, from the lowest: compounds 4, 1 and 3 (each within the scatter of the next); then compound 2.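

In this assay, the steps of a 1.6-fold lower number from compound 3 to compound 4 (0.22 log units; within the scatter) and a 1.3-fold lower number from compound 1 to compound 4 (0.10 log units; within the scatter) show that this nitrogen can carry 4-chloro-3-(methoxycarbonyl)phenyl, with its double bond outside the ring and its second hydrogen-bond acceptor, without leaving the scatter. With a 10-fold lower number from compound 2 to compound 4 (1.01 log units; beyond the scatter) as well, compound 2 alone stands apart among the four compounds. Nothing available explains this difference. On these data alone, whether a carboxylic acid or an amide in place of the methoxycarbonyl group would stay at this level remains open. So does whether any group on this nitrogen can give a number beyond the scatter below those of compounds 1, 3 and 4.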